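Methoxy in Place of Methyl: An Expected Flat Step

This account rests on a few compounds, and the source may have more. Where it says the series, first, only, none or still open, it means among the compounds named here.

compound 1 `Cc1ccc(S(=O)(=O)c2n[nH]c3ccc(N4CCN(C)CC4)cc23)cc1`: 100%
compound 2 `CN1CCN(c2ccc3c(c2)c(S(=O)(=O)c2cccc4ccccc24)nn3Cc2ccccc2)CC1`: 100%
compound 3 `CCCn1nc(S(=O)(=O)c2cccc3ccccc23)c2cc(N3CCNCC3)ccc21`: 99%

All three measured compounds share a core and differ in the groups around it. In a functional assay on HeLa cells for antagonist activity at 5-hydroxytryptamine receptor 6 (Homo sapiens) (a lower number here means a smaller maximal response, a higher number a larger maximal response), compound 1 gives 100%, level at the digits shown with compound 2, and the two together stand highest of the three numbers. Compound 3 gives 99% in this assay, a value that differs from compound 1 only within the usual scatter. No pair among these three differs in a single place, so no measured step is available as a guide.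

Compound 4 `COc1ccc(S(=O)(=O)c2n[nH]c3ccc(N4CCN(C)CC4)cc23)cc1` is the unmeasured compound. It differs from compound 1 in one place: methoxy in place of methyl on an aromatic carbon. With every measured compound sitting at essentially the same maximal response in this assay, there is nothing to suggest that this change moves the number in either direction. The step of a number 1 percentage points lower from compound 1 to compound 4 (within the scatter) is therefore expected to stay within the scatter. Compound 4 is estimated to give 99% in this assay, with a likely range from 90% to 104%.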

Compound 4, largest response reached (reported as Imax), in percent of the reference or control that the assay uses: 100%
Compound 4: middle estimate off by 1 percentage points, on the low side, within the range that was stated.
By their numbers in this assay, from the lowest: compounds 3, 1, 2 and 4 (each within the scatter of the next).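

Methoxy in place of methyl on an aromatic carbon, para to a large group, gives in this assay no change at the digits printed from compound 1 to compound 4 (within the scatter). Within the data shown here, this is the first comparison in the set that isolates a single place, since the earlier compounds differ from one another in several groups at once. It shows directly that, on the shared core of compound 1, going from 4-methylphenyl to 4-methoxyphenyl adds an oxygen and a hydrogen-bond acceptor without a step beyond the scatter, and no measurement shown here offers an explanation for this result.

The compounds shown leave open whether an amine, a carboxylic acid or a longer chain such as ethoxy at this place would also remain level with compound 1. They also leave open whether the same exchange would read alike alongside the other groups carried by compound 2 and compound 3.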